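This account rests on a few compounds, and the source may have more. Where it says the series, first, only, none or still open, it means among the compounds named here.

Measured so far in an in vitro functional assay on Ltk cells for inhibition of metabotropic glutamate receptor 5 (Homo sapiens), read by calcium flux; on this read-out lower numbers stand for stronger inhibition and higher numbers for weaker inhibition:

Compound 1, `C(#Cc1ccccn1)C1=CC(Sc2ccc3ccccc3c2)CCC1`, gives 213 nM.
Compound 2, `CC(C)(C)OC(=O)N1CC=C(C#Cc2ccccn2)CC1`, gives 2.6 nM.
Compound 3, `C(#Cc1ccccn1)C1=CCNCC1`, gives 580 nM.

Compound 2 stands lowest of the three numbers in this assay; compound 1 is nearest with a number that is higher beyond the scatter, and compound 3 is furthest. The new compound 4, `O=C(Oc1ccccc1)N1CC=C(C#Cc2ccccn2)CC1`, differs from compound 2 in one place: phenyl in place of tert-butyl on an oxygen next to a carbonyl group. Among the compounds with values here, only one measured step touches this part of the molecule, and it does not change the group on the oxygen but removes the whole carbamate: a 220-fold higher number from compound 2 to compound 3 (2.35 log units; beyond the scatter). Within the data shown here, that step shows the carbamate counts for a great deal, but no measured pair shows what an exchange of the group on its oxygen does. The carbonyl and the ring nitrogen it sits on are kept in compound 4, so a step of modest size in this assay is expected, with no firm direction, most likely towards a somewhat higher number. For compound 4 the step from compound 2 is estimated as a 2.3-fold higher number from compound 2 to compound 4 (0.36 log units; beyond the scatter). Compound 4 is therefore expected to give about 6 nM in this assay, between 1.5 nM and 30 nM.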

Compound 4, half-maximal inhibitory concentration: 35 nM
Compound 4: middle estimate off by 5.8-fold (0.77 log units), on the low side, outside the stated range (above it).
By their numbers in this assay, from the lowest: compound 2; then compound 4; then compound 1; then compound 3.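

In this assay, the group on the carbamate oxygen proved to matter in its own right: with the carbonyl and the ring nitrogen kept, phenyl in place of tert-butyl still gives a 13-fold higher number from compound 2 to compound 4 (1.13 log units; beyond the scatter). This single exchange thus accounts for a large step, though a smaller one than removing the whole carbamate, which gives a 220-fold higher number from compound 2 to compound 3 (2.35 log units; beyond the scatter). Nothing available explains why this exchange has such an effect.

With only tert-butyl and phenyl to compare at this position, the compounds shown leave open whether the ring itself or the loss of tert-butyl drives the step. As far as these compounds go, how methyl, ethyl, isopropyl or benzyl would behave on this oxygen remains open, as does whether a urea or an amide could take the place of the carbamate.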